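The source may report more compounds than this note shows. Statements on the series, on what has been measured and on what is new or still open speak of the compounds shown alone.

Compound 1 `N#Cc1cnc(NCc2cnccc2C(F)(F)F)cc1N[C@H]1C[C@@H](O)C1` in an assay on isolated protein for inhibition of protein kinase C delta type (Homo sapiens), read by TR-FRET, with a stated time of 2 h; a lower number here means a stronger inhibitor, a higher number a weaker inhibitor: > 10000 nM. Compound 2 `N#Cc1cnc(NCc2ccccc2C(F)(F)F)cc1N[C@H]1CC[C@@H](C(N)=O)CC1` in this assay: 640 nM.

The figure for compound 1 is a limit of the assay, not a number, so compound 1 stands at the limit of > 10000 nM in this assay, at which 1 of the 2 values shown sits. Among the measured compounds shown here, compound 2 gives 640 nM, the one measured number here. Compound 3 `CC1(C)C[C@H](Nc2cc(NCc3cnccc3C(F)(F)F)ncc2C#N)CC[C@H]1O` differs from compound 1 by 4-hydroxy-3,3-dimethylcyclohexyl in place of 3-hydroxycyclobutyl on a nitrogen on an aromatic ring. For the measured compounds named here, no step between measured compounds covers this change, so any expectation rests on the two values alone; a moderate step toward stronger inhibition is expected. Compound 3 is therefore estimated at 2500 nM, with a range from 500 nM to 10000 nM. The expected step reads an at least 4.0-fold lower number from compound 1 to compound 3 (0.60 log units; beyond the scatter).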

Compound 3, half-maximal inhibitory concentration: 2200 nM
Beside the measured number, compound 3's estimate is 1.1-fold (0.06 log units) above it, within the range that was stated.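

In this assay, 4-hydroxy-3,3-dimethylcyclohexyl in place of 3-hydroxycyclobutyl on a nitrogen on an aromatic ring gives an at least 4.5-fold lower number from compound 1 to compound 3 (0.65 log units; beyond the scatter), so the group at this position can move the value beyond the scatter. The true size of this step stays open on one side, because the figure for compound 1 is a limit of the assay and not a number: the limit of > 10000 nM in this assay, at which 1 of the 3 values shown sits.

The change alters ring size and adds two methyl groups at once, and the compounds shown do not separate these two changes. From the compounds shown here alone, how an amine or a carboxylic acid in place of the hydroxyl on the cyclohexyl ring would read remains open.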